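Dihydro-fused dimethoxy amide series: anilide variation

A few compounds are considered here, and "the series" means these few. Any claim that something is new, unique, unknown or untested is made for them only; others in the source may bear on it.

Measured so far:
compound 1, `COc1cc2c(cc1OC)C(CC(=O)Nc1ccc(Br)cc1)CC2`, 66.7% in a functional assay on the whole organism (strain Wistar) for inhibition, with Rattus norvegicus as the target, read by paw edema, with a stated time of 24 h, at a dose of 100 mg/kg; a higher number here means more inhibition at the dose given (going by the name of the read-out), a lower number less inhibition
compound 2, `COc1cc2c(cc1OC)C(CC(=O)Nc1cccc(C)c1)CC2`, 41.7% in this assay

Compound 2 stands lowest of the two numbers; the only step shown, a number 25 percentage points lower from compound 1 to compound 2 (beyond the scatter), runs against it. Compound 3, `COc1cc2c(cc1OC)C(CC(=O)Nc1ccc(C)cc1)CC2`, has not been measured in this assay. The change from compound 2 to compound 3 is 4-methylphenyl in place of 3-methylphenyl on an amide-type nitrogen.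

Among the measured compounds shown here, no measured step bears directly on this change: the step from compound 1 to compound 2 swaps 4-bromophenyl for 3-methylphenyl, which alters both the group and its place at once, so it cannot be split into a part for the group and a part for the place. For the measured compounds named here, the single step in the set is modest in size, and a move within the same group is not expected to exceed it. The step of a number 8.3 percentage points higher from compound 2 to compound 3 (within the scatter) is therefore estimated as small, most likely within the scatter, with direction uncertain. For compound 3 the expected value in this assay is 50%, estimated to lie between 30% and 70%.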

Compound 3, a percentage reported as inhibition, in the whole organism at one dose (the size of the read-out at that dose, not a potency): 30%
For compound 3 the middle estimate is 20 percentage points above the measured one; measured number inside the range.
By their numbers in this assay, from the lowest: compound 3; then compound 2; then compound 1.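

In this assay, 4-methylphenyl in place of 3-methylphenyl on the amide-type nitrogen gives a number 11.7 percentage points lower from compound 2 to compound 3 (beyond the scatter), so with the group unchanged, its place alone moves the number beyond the scatter, which the earlier pair could not show. Keeping the place and exchanging the group, methyl in place of bromo on an aromatic carbon gives a number 36.7 percentage points lower from compound 1 to compound 3 (beyond the scatter), so the group also matters on its own, and this step is the larger of the two. Nothing available bears on the reason for either step.

Going by these compounds, what a 3-bromophenyl group gives on the same nitrogen stays open, and with it whether the two places rank the same for bromo as for methyl. Also open, on these data alone, is how an unsubstituted phenyl or a 4-methoxyphenyl group compares with these three.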